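Replacing a sulfonamide with a fluorinated chain on the shared core

This account rests on a few compounds, and the source may have more. Where it says the series, first, only, none or still open, it means among the compounds named here.

Compounds measured so far, with their values in an assay on CHO-K1 cells for inhibition of 11-beta-hydroxysteroid dehydrogenase type 2 (Homo sapiens), read by scintillation proximity assay; a lower number here means a stronger inhibitor, a higher number a weaker inhibitor:
compound 1, `Cn1c(-c2ccccc2C(F)(F)F)nnc1C12CCC(CCS(C)(=O)=O)(CC1)CC2`: > 4000 nM
compound 2, `Cn1c(-c2ccccc2C(F)(F)F)nnc1C12CCC(CNS(C)(=O)=O)(CC1)CC2`: > 4000 nM

Compound 2 gives only a limit of this assay, > 4000 nM, not a number. Compound 1 likewise gives only a limit, > 4000 nM. Both values sit at the limit of > 4000 nM in this assay, at which 2 of the 2 values shown sit, so the step that the two limits leave unreadable from compound 1 to compound 2 cannot be read, and compound 2 stands among values that are all limits.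

Compound 3, `Cn1c(-c2ccccc2C(F)(F)F)nnc1C12CCC(CCCC(C)(F)F)(CC1)CC2`, differs from compound 2 by a group of 6 heavy atoms (4 carbon, 2 fluorine; no ring) in place of a group of 5 heavy atoms (1 carbon, 1 nitrogen, 2 oxygen, 1 sulfur; no ring), on a saturated chain carbon bound to a saturated ring carbon. Within the data shown here, the only measured step bears on it merely by showing that two groups at this position both leave the compound at the limit; its size is not readable. Among the measured compounds shown here, no measured step therefore points to a change beyond the scatter, in either direction, and the most likely outcome is again a limit.

Compound 3 is expected to give 6000 nM, with a range from 1500 nM to 30000 nM. The expected step that the limit leaves unreadable from compound 2 to compound 3 is an estimate that assumes no change beyond the scatter.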

Compound 3, half-maximal inhibitory concentration: > 4000 nM
Compound 3: no number, only a limit; the forecaster's own chance of this, stated with the estimate: 70%; the middle value does not contradict the limit.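

Among these compounds, compound 3 gives > 4000 nM in this assay as a limit and not a number, so no step among compound 1, compound 2 and compound 3 can be read. On these data alone, how strongly each of these three compounds inhibits the enzyme remains open.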